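A few compounds are considered here, and "the series" means these few. Any claim that something is new, unique, unknown or untested is made for them only; others in the source may bear on it.

Measured so far:
- compound 1, `CC(C)OC(=O)N1CCC(Oc2ncnc3c2CCN3c2ccc(S(C)(=O)=O)cc2F)CC1`: 50.1 nM
- compound 2, `CC(C)OC(=O)N1CCC(Oc2ncnc3c2CCN3c2ccc(S(C)(=O)=O)nc2)CC1`: 251 nM
- compound 3, `CC(C)OC(=O)N1CCC(Oc2ncnc3c2CCN3c2ccc(C#N)cn2)CC1`: 794 nM

All three share one core and differ only in the aryl group on the ring nitrogen. In a functional assay on CHO-K1 cells for agonist activity at Glucose-dependent insulinotropic receptor (Homo sapiens), read by a luciferase reporter, with a stated time of 5 h (on this read-out higher numbers stand for an effect only at larger amounts of compound and lower numbers for an effect already at smaller amounts), compound 1 gives the lowest number, compound 2 a higher one (a 5.0-fold higher number from compound 1 to compound 2 (0.70 log units; beyond the scatter)), and compound 3 the highest of the three (a 16-fold higher number from compound 1 to compound 3 (1.20 log units; beyond the scatter) and a 3.2-fold higher number from compound 2 to compound 3 (0.50 log units; beyond the scatter)). Compound 3 thus stands at the weak end of the series in this assay.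

Compound 4, `CC(C)OC(=O)N1CCC(Oc2ncnc3c2CCN3c2ccc(F)cn2)CC1`, keeps the core and the pyridinyl group of compound 3 and differs from it only here: fluoro in place of cyano on an aromatic carbon. Going by the values given here, none of the measured steps touches this particular exchange; each of them swaps the whole aryl group rather than a single substituent on it. Among the compounds with values here, what the series does show is that the aryl substituent pattern shifts this assay across a wide span, and that the sole cyano-bearing compound sits at the top of the numbers. Losing the cyano for a fluoro is therefore expected to move compound 4 no lower, and more likely somewhat higher, in this assay, with a step estimated at a 2.0-fold higher number from compound 3 to compound 4 (0.30 log units; within the scatter). For compound 4 the expected value in this assay is 1600 nM, within a range from 500 nM to 5000 nM.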

Compound 4, half-maximal effective concentration: > 10000 nM
Compound 4: only a limit was reported (the forecaster's own chance of this, stated with the estimate: 15%); middle value at least 6.2-fold (0.79 log units) from the limit.
By their numbers in this assay, from the lowest: compound 1; then compound 2; then compound 3. At a limit, above all of these: compound 4.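

In this assay the exchange of cyano for fluoro on this aromatic carbon, para to a large group, gives an at least 12-fold higher number from compound 3 to compound 4 (1.10 log units; beyond the scatter) on a single substituent, so this one position alone can carry a large shift, which the whole-aryl swaps could not show. Measured against the two methylsulfonyl-bearing aryl groups, the same compound lies still further off, with an at least 39-fold higher number from compound 2 to compound 4 (1.60 log units; beyond the scatter) and an at least 190-fold higher number from compound 1 to compound 4 (2.30 log units; beyond the scatter) as the steps. The entry for compound 4 is a limit of the assay and not a number: the limit of > 10000 nM in this assay, at which 1 of the 4 values shown sits.

Going by these compounds, how far compound 4 lies beyond that limit therefore stays open. Also open, on these data alone, is what a methyl, an amine or a carboxamide would do on this same carbon, and whether any of them would come close to the cyano of compound 3.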